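A few compounds are considered here, and "the series" means these few. Any claim that something is new, unique, unknown or untested is made for them only; others in the source may bear on it.

Of the compounds shown here, three with a shared core have been measured in an assay on isolated protein for inhibition of cathepsin S (Homo sapiens), read by fluorescence; on this read-out lower numbers stand for stronger inhibition and higher numbers for weaker inhibition. Compound 1 `N#Cc1nc(-c2cccc(C(F)(F)F)c2)cc2[nH]cnc12` carries a bare core and gives 1050 nM. Compound 2 `CCOc1ccc(-c2cc3c(ncn3CCCN(C)C)c(C#N)n2)cc1C(F)(F)F`, with an ethoxy group on its outer ring and a chain on the core, gives 27 nM. Compound 3 `Cn1cnc2c(C#N)nc(-c3ccc(CCO)c(C(F)(F)F)c3)cc21` gives 71 nM, which places it second highest of the three numbers: its nearest neighbour is compound 2, and its value lies well beyond the usual scatter from that of compound 1.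

The step from compound 3 to compound 4 `Cn1cnc2c(C#N)nc(-c3ccc(OCCN4CCCC4=O)c(C(F)(F)F)c3)cc21` exchanges one group on the outer ring: 2-(2-oxopyrrolidin-1-yl)ethoxy in place of 2-hydroxyethyl on an aromatic carbon. The new group sits on an aromatic carbon of a six-membered aromatic ring of carbon only, ortho to a trifluoromethyl group and para to a large group, and it brings a five-membered non-aromatic ring where the 2-hydroxyethyl chain had none.

Compound 2 and compound 3 show that larger groups on this position go together with lower numbers than the bare ring of compound 1, so a further extension is expected to be tolerated. The expected step in this assay from compound 3 to compound 4 is a 1.4-fold lower number from compound 3 to compound 4 (0.15 log units; within the scatter), a small change in the direction of stronger inhibition or none beyond the scatter. For compound 4 the estimate is 50 nM, with a range from 15 nM to 160 nM.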

Compound 4, half-maximal inhibitory concentration: 7.8 nM
For compound 4 the middle estimate is 6.4-fold (0.81 log units) above the measured one, outside the stated range (below it).
By their numbers in this assay, from the lowest: compound 4; then compound 2; then compound 3; then compound 1.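

In this assay, placing 2-(2-oxopyrrolidin-1-yl)ethoxy in place of 2-hydroxyethyl gives a 9.1-fold lower number from compound 3 to compound 4 (0.96 log units; beyond the scatter), so this position, ortho to a trifluoromethyl group, does more than accept a larger group: changing this one group moves the number well beyond the usual scatter. The entering group has no hydrogen-bond donor, whereas 2-hydroxyethyl has one, so in this pair a donor at this position is not needed for the lower number. Nothing available explains the size of this step, and the exchange alters several features at once, including the ring, the carbonyl and the oxygen attached to the aromatic carbon.

The compounds shown do not separate these features, so it remains open whether a pyrrolidine ring without its carbonyl, an open-chain amide or a simple 2-methoxyethoxy chain would give a similar number. Compound 2 carries an ethoxy group on its outer ring, but it also differs from compound 3 and compound 4 by the chain on its core, so it cannot settle how much of the step comes from the oxygen link alone.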